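The compounds below may be only part of what the source reports. "The series", "measured", "known", "first", "only" and "open" are said of these compounds alone.

Compound 1, `Nc1cc(N)c2nc(-c3ccccc3)c(Oc3ccc(Cl)c(Cl)c3)nc2c1`: 66100 nM in a functional assay on SK-OV-3 cells (Homo sapiens) for inhibition, read by sulforhodamine B assay, with a stated time of 48 h; on this read-out lower numbers stand for stronger inhibition of growth and higher numbers for weaker inhibition of growth.
Compound 2, `CCOC(=O)[C@H](CCC(=O)O)NC(=O)c1ccc(Sc2nc3cc(N)cc(N)c3nc2-c2ccccc2)cc1`: 44700 nM in this assay.

Both numbers are high, so on this read-out both compounds inhibit the growth of these cells only weakly. Compound 1 has the highest of the two numbers, but compound 2 sits within the usual scatter of it, so the two cannot be ranked against each other. Compound 3, `Nc1cc(N)c2nc(-c3ccccc3)c(Sc3ccc(Cl)c(Cl)c3)nc2c1`, has not yet been measured. It differs from compound 1 in one place: (3,4-dichlorophenyl)sulfanyl in place of 3,4-dichlorophenoxy on an aromatic carbon. Among the compounds with values here, compound 2 also joins its aryl group to the shared core through sulfur, but with a different aryl group, so no measured pair isolates the exchange of oxygen for sulfur alone. With both measured compounds weak and indistinguishable from each other, the step from compound 1 to compound 3 is expected to be small, in either direction or none at all beyond the scatter, as a 1.3-fold lower number from compound 1 to compound 3 (0.12 log units; within the scatter). In this assay compound 3 is therefore estimated to give about 50000 nM, with a range from 20000 nM to 130000 nM.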

Compound 3, concentration for total growth inhibition: 39800 nM
The estimate for compound 3 lay 1.3-fold (0.10 log units) above the measured number, and the stated range covers the measured number.
By their numbers in this assay, from the lowest: compounds 3, 2 and 1 (each within the scatter of the next).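

In this assay, within the data shown here, placing (3,4-dichlorophenyl)sulfanyl where compound 1 carries 3,4-dichlorophenoxy gives a 1.7-fold lower number from compound 1 to compound 3 (0.22 log units; within the scatter), the first reading in which the linking atom at this carbon is the only difference between two compounds. Among these compounds, compound 2 also carries a sulfur link, but with another aryl group, so only this pair isolates the exchange of oxygen for sulfur, and the two compounds cannot be told apart on this read-out. At this position, with the 3,4-dichlorophenyl group kept, the choice between the oxygen and sulfur links therefore leaves growth inhibition weak, and nothing measured here accounts for the result.

Still open, from the compounds shown here alone, is whether an amine or a methylene link at this carbon, or a longer chain between the core and the ring, would give a number clearly apart from these. Going by these compounds, it is also open whether an unsubstituted phenyl ring or one bearing a carboxylic acid, in place of the 3,4-dichlorophenyl group, would change how this position responds to the exchange of oxygen for sulfur.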